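The source may report more compounds than this note shows. Statements on the series, on what has been measured and on what is new or still open speak of the compounds shown alone.

Measured so far:
- compound 1, `COc1ccc(C2=NN(C3=NC(=O)/C(=C4\C(=O)Nc5ccccc54)S3)C(c3ccc(OC)cc3)C2)cc1`: 100000 nM
- compound 2, `O=C1N=C(N2N=C(c3ccccc3)CC2c2ccc(Cl)cc2)S/C1=C1/C(=O)Nc2ccccc21`: 850 nM

Of the compounds shown here, two share a core and have been tested in a functional assay on cells (Cancer cell lines, Homo sapiens) for cytotoxicity, read by sulforhodamine B assay, with a stated time of 48 h; on this read-out lower numbers stand for stronger inhibition of growth and higher numbers for weaker inhibition of growth. Compound 2 gives 850 nM, the lowest number of the pair. Within the data shown here, compound 1 gives 100000 nM, a far higher number that lies well beyond the usual scatter; the two structures differ in more than one place, so the two values alone say only that compound 1 inhibits growth much more weakly.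

Compound 3, `COc1ccc(C2=NN(C3=NC(=O)/C(=C4\C(=O)Nc5ccccc54)S3)C(c3ccc(Cl)cc3)C2)cc1`, has not yet been measured. It differs from compound 2 by one change: methoxy in place of hydrogen on an aromatic carbon. This brings compound 3 one step closer to compound 1, which gives 100000 nM. For that reason the expectation is a clear step upward in this assay for compound 3, toward weaker inhibition of growth, larger than the scatter but short of the whole distance to compound 1, since compound 3 keeps the chlorine that compound 1 lacks. The expected step is a 5.9-fold higher number from compound 2 to compound 3 (0.77 log units; beyond the scatter). The estimate for compound 3 is therefore 5000 nM, with a range from 1000 nM to 40000 nM.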

Compound 3, concentration for total growth inhibition: 100000 nM
The estimate for compound 3 lay 20-fold (1.30 log units) below the measured number; measured number outside the range, above it.
By their numbers in this assay, from the lowest: compound 2; then compounds 1 and 3 (each within the scatter of the next).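

Changing phenyl to 4-methoxyphenyl gives a 120-fold higher number from compound 2 to compound 3 (2.07 log units; beyond the scatter) in this assay, so this single position can by itself separate a compound that stops cell growth at a modest concentration from one that needs a far higher concentration. The earlier pair could not show this, since compound 1 and compound 2 differ in more than one place. The other new comparison, chloro in place of methoxy on an aromatic carbon, gives no change at the digits printed from compound 1 to compound 3 (within the scatter), so with the 4-methoxyphenyl group in place, this second swap makes no visible difference, and the chloro group of compound 2 is not enough to keep its low number once the methoxy group is present. Nothing available explains why the methoxy group has so large an effect here.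

On these data alone, it remains open whether the loss belongs to methoxy alone or would also follow from another group on the same carbon, such as fluoro, hydroxyl or an amine. Among these compounds, it is also open what the chloro group contributes when that position carries only hydrogen, since no compound here has phenyl paired with a different group in place of that chloro.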